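Trimethoxyphenyl regioisomers in the semicarbazone series

The source may hold more compounds than are shown below. What is called first, only, known or untested is meant among the compounds shown, and "the series" means these compounds.

Measured so far in a functional assay on MKN-45 cells (Homo sapiens) for cytotoxicity, read by MTT assay, with a stated time of 72 h; a lower number here means a stronger inhibitor, a higher number a weaker inhibitor:
compound 1 `CN(C)CCn1cnnc1-c1cc(Oc2ccc(NC(=O)N/N=C/c3ccc(O)c(O)c3)cc2F)ccn1` gives 3240 nM;
compound 2 `COc1ccc(/C=N/NC(=O)Nc2ccc(Oc3ccnc(-c4nncn4CCN(C)C)c3)c(F)c2)c(OC)c1OC` gives 2020 nM.

Compound 2 shows the lower of the two numbers, yet the step of a 1.6-fold lower number from compound 1 to compound 2 (0.21 log units; within the scatter) falls within the scatter, so the pair stands level. Compound 3 `COc1cc(/C=N/NC(=O)Nc2ccc(Oc3ccnc(-c4nncn4CCN(C)C)c3)c(F)c2)cc(OC)c1OC` differs from compound 2 by 3,4,5-trimethoxyphenyl in place of 2,3,4-trimethoxyphenyl on a carbon with a double bond to nitrogen. Among the compounds with values here, no measured step rearranges methoxy groups on this ring; the only comparison at this place, a 1.6-fold lower number from compound 1 to compound 2 (0.21 log units; within the scatter), exchanged the whole aryl group and stayed within the scatter. No step beyond the scatter is therefore expected for compound 3 in this assay. Compound 3 is estimated at 2000 nM, between 700 nM and 6000 nM, with an expected step of a 1.0-fold lower number from compound 2 to compound 3 (0.00 log units; within the scatter).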

Compound 3, half-maximal inhibitory concentration: 2900 nM
For compound 3 the middle estimate is 1.5-fold (0.16 log units) below the measured one; measured number inside the range.
By their numbers in this assay, from the lowest: compounds 2, 3 and 1 (each within the scatter of the next).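

In this assay, rearranging the methoxy groups from 2,3,4-trimethoxyphenyl to 3,4,5-trimethoxyphenyl gives a 1.4-fold higher number from compound 2 to compound 3 (0.16 log units; within the scatter) and so leaves the pair level. Exchanging 3,4-dihydroxyphenyl for 3,4,5-trimethoxyphenyl gives a 1.1-fold lower number from compound 1 to compound 3 (0.05 log units; within the scatter) and so shows no separation either, leaving all three aryl groups on the carbon with a double bond to nitrogen level. Nothing available explains this flat result.

Open, on these data alone, is whether an unsubstituted phenyl, a 4-carboxyphenyl or a 4-aminophenyl group at this place would move the number beyond the scatter.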